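Acrylamide warhead variants on a shared core: antiproliferative notes

A few compounds are considered here, and "the series" means these few. Any claim that something is new, unique, unknown or untested is made for them only; others in the source may bear on it.

Measured so far in a functional assay on HepG2 cells (Homo sapiens) for antiproliferative activity, read by MTT assay, with a stated time of 72 h; on this read-out lower numbers stand for stronger inhibition and higher numbers for weaker inhibition:
- compound 1 `C=C(Cl)C(=O)Nc1cc(Nc2nccc(-c3cn(C)c4ccccc34)n2)c(OC)cc1N(C)CCN(C)C` gives 1390 nM
- compound 2 `COc1cc(N(C)CCN(C)C)c(NC(=O)C(Cl)=C(Cl)Cl)cc1Nc1nccc(-c2cn(C)c3ccccc23)n1` gives > 50000 nM
- compound 3 `C/C=C\C(=O)Nc1cc(Nc2nccc(-c3cn(C)c4ccccc34)n2)c(OC)cc1N(C)CCN(C)C` gives 6930 nM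

The value of compound 2 is a limit of this assay, not a number, as the limit of > 50000 nM in this assay, at which 1 of the 3 values shown sits, records. Among the numbers that are not limits, compound 1 stands lowest; its nearest neighbour is compound 3, reached by a 5.0-fold higher number from compound 1 to compound 3 (0.70 log units; beyond the scatter).

Both measured steps alter the group on the carbonyl carbon. Replacing 1-chloroethenyl by 1,2,2-trichloroethenyl gives an at least 35-fold higher number from compound 1 to compound 2 (1.55 log units; beyond the scatter); replacing it by prop-1-en-1-yl gives a 5.0-fold higher number from compound 1 to compound 3 (0.70 log units; beyond the scatter); and between the two alternatives there is an at least 7.2-fold lower number from compound 2 to compound 3 (0.85 log units; beyond the scatter). Every change away from 1-chloroethenyl so far has raised the number beyond the scatter.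

Compound 4 `COc1cc(N(C)CCN(C)C)c(NC(=O)C=C(C)C)cc1Nc1nccc(-c2cn(C)c3ccccc23)n1` is not yet measured. It differs from compound 1 as follows: 2-methylprop-1-en-1-yl in place of 1-chloroethenyl on a carbonyl carbon. Within the data shown here, the closest measured step is the one to compound 3, which also put a carbon substituent on the ethenyl in place of the chlorine, and compound 4 carries one carbon group more on that ethenyl than compound 3 does.

Compound 4 is therefore expected to give a higher number than compound 1 in this assay, with a step estimated at an 11-fold higher number from compound 1 to compound 4 (1.03 log units; beyond the scatter). Compound 4 is expected to land near 15000 nM, with a plausible range from 5000 nM to 50000 nM.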

Compound 4, half-maximal inhibitory concentration: 5660 nM
Compound 4: the middle estimate sits 2.7-fold (0.42 log units) above what was measured; the measured number falls inside the stated range.
By their numbers in this assay, from the lowest: compound 1; then compounds 4 and 3 (each within the scatter of the next). At a limit, above all of these: compound 2.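

In this assay, the extra methyl group on the ethenyl leaves the read-out where it was, with a 1.2-fold lower number from compound 3 to compound 4 (0.09 log units; within the scatter), so prop-1-en-1-yl and 2-methylprop-1-en-1-yl cannot be told apart on this carbonyl carbon. Compound 1 keeps its separation from this second carbon-substituted group, with a 4.1-fold higher number from compound 1 to compound 4 (0.61 log units; beyond the scatter), yet chlorine on the ethenyl does not by itself give the lower number: compound 2 goes against any such pattern, with an at least 8.8-fold lower number from compound 2 to compound 4 (0.94 log units; beyond the scatter). The value of compound 2 is a limit of the assay and not a number: the limit of > 50000 nM in this assay, at which 1 of the 4 values shown sits.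

The compounds shown leave open whether the lower number of compound 1 goes with chlorine as such or with having any substituent at that ethenyl carbon, and an unsubstituted ethenyl, a 1-fluoroethenyl or a 1-bromoethenyl on the same carbonyl carbon would separate these readings. Also open, from the compounds shown here alone, is how a longer chain ending in a dimethylamino group on the ethenyl would compare with prop-1-en-1-yl and 2-methylprop-1-en-1-yl on the shared core.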